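This account rests on a few compounds, and the source may have more. Where it says the series, first, only, none or still open, it means among the compounds named here.

Measured compounds:
Compound 1 `C1CN=C(NC(C2CC2)C2CC2)C1` gives 513 nM in an assay (Bos taurus) for displacement of a labelled ligand from Nischarin (Homo sapiens); a lower number here means a stronger inhibitor, a higher number a weaker inhibitor.
Compound 2 `CC1CCN=C1NC(C1CC1)C1CC1` gives only a limit of the assay, < 10000 nM, in this assay.

Compound 1 carries the only number shown; the other value is a limit. The unmeasured compound 3 `CC1CN=C(NC(C2CC2)C2CC2)C1` differs from compound 1 by a single change: methyl in place of hydrogen on a saturated ring carbon. Among the compounds with values here, the only measured step of the same kind, a step that the limit leaves unreadable from compound 1 to compound 2, places a methyl on a different ring carbon of the shared core and ends at the limit (the limit of < 10000 nM in this assay, at which 1 of the 2 values shown sits), so its size cannot be read. Within the data shown here, no measured step therefore gives the size or direction of the change into compound 3, beyond the fact that a methyl elsewhere on the same ring gave only a limit. Compound 3 is expected to give 1500 nM, within 300 nM to 8000 nM. The expected step of a 2.9-fold higher number from compound 1 to compound 3 (0.47 log units; beyond the scatter) is estimated as a weakening, held with little confidence.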

Compound 3, inhibition constant: 646 nM
For compound 3 the middle estimate is 2.3-fold (0.37 log units) above the measured one; the range from low to high includes it.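

Measured in this assay the methyl on a saturated ring carbon, two ring bonds from the ring nitrogen, gives a 1.3-fold higher number from compound 1 to compound 3 (0.10 log units; within the scatter) so compound 1 and compound 3 cannot be told apart at this position. Within the data shown here, this is the first readable size for a methyl placed on this ring of the shared core, and it shows that this one added group can sit here while a measurable number is kept. The methyl on a different ring carbon, in compound 2, cannot be set against it, since that value is a limit: the limit of < 10000 nM in this assay, at which 1 of the 3 values shown sits.

From the compounds shown here alone, what an ethyl, a hydroxyl, an amine or a carboxylic acid would do on the same ring carbon stays open. With no number for the methyl at the other ring carbon, the two places cannot yet be ranked.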